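The source may report more compounds than this note shows. Statements on the series, on what has been measured and on what is new or still open speak of the compounds shown alone.

Measured so far in a functional assay on MCF7 cells (Homo sapiens) for antiproliferative activity, read by MTT assay, with a stated time of 72 h; a lower number here means a stronger inhibitor, a higher number a weaker inhibitor:
compound 1 `O=C(N/N=C/c1ccc(F)cc1)Nc1ccc(Oc2ccnc3[nH]ccc23)cc1`: 3720 nM
compound 2 `O=C(N/N=C/c1ccc(O)cc1)Nc1ccc(Oc2ccnc3[nH]ccc23)cc1`: 5800 nM

For the measured compounds named here, with only two numbers available, compound 2 has no clear rank: the only measured step, a 1.6-fold higher number from compound 1 to compound 2 (0.19 log units; within the scatter), lies within the scatter, so the two compounds cannot be ordered.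

Compound 3 `O=C(N/N=C/c1ccc(O)cc1Br)Nc1ccc(Oc2ccnc3[nH]ccc23)cc1` is the next analogue of compound 2. The change is bromo in place of hydrogen on an aromatic carbon, which turns 4-hydroxyphenyl into 2-bromo-4-hydroxyphenyl.

Going by the values given here, the one measured step bears on this only indirectly. Among the compounds with values here, it swaps one group for another on the same aromatic ring, and no measured compound carries a group at the new place. The data therefore give no direct size for this change. Within the data shown here, they show only that one substituent swap on this ring, a 1.6-fold higher number from compound 1 to compound 2 (0.19 log units; within the scatter), stayed within the scatter.

The expectation starts from compound 2 at 5800 nM in this assay. The expected step, a 1.3-fold lower number from compound 2 to compound 3 (0.11 log units; within the scatter), is no larger than the scatter, with no firm direction.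

For compound 3 the estimated value is 4500 nM, with an expected range of 1700 nM to 11000 nM.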

Compound 3, half-maximal inhibitory concentration: "not active" (no number reported)
The entry for compound 3 holds no number; no gap can be computed for the estimate.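

For the compounds shown here, compound 3 is entered as "not active" without a number in this assay, so no step from compound 2 to compound 3 can be read. No supporting data bear on this entry. The compounds shown leave open how large the change from 4-hydroxyphenyl to 2-bromo-4-hydroxyphenyl is in this assay.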